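Moving a Trifluoromethyl Group on a Shared Core

A few compounds are considered here, and "the series" means these few. Any claim that something is new, unique, unknown or untested is made for them only; others in the source may bear on it.

Compound 1 `Oc1cccc(-c2cc(-c3ccccc3C(F)(F)F)cc(-c3ccccc3O)n2)c1` gives 5680 nM in a functional assay on T47D cells (Homo sapiens) for inhibition; a higher number here means a weaker inhibitor, a lower number a stronger inhibitor. Compound 2 `Oc1cccc(-c2cc(-c3cccc(C(F)(F)F)c3)cc(-c3ccccc3O)n2)c1` gives 6340 nM. Compound 3 `Oc1ccc(-c2cc(-c3ccccc3C(F)(F)F)cc(-c3cccc(O)c3)n2)cc1` gives 3210 nM.

All three share one core. Compound 4 `Oc1ccc(-c2cc(-c3cccc(C(F)(F)F)c3)cc(-c3cccc(O)c3)n2)cc1` is not yet measured; it differs from compound 3 in one place: 3-(trifluoromethyl)phenyl in place of 2-(trifluoromethyl)phenyl on an aromatic carbon. The same kind of change links compound 1 and compound 2: 3-(trifluoromethyl)phenyl in place of 2-(trifluoromethyl)phenyl on an aromatic carbon. The surroundings differ: in compound 1 the place is meta to a 2-hydroxyphenyl group and a 3-hydroxyphenyl group, in compound 3 meta to a 3-hydroxyphenyl group and a 4-hydroxyphenyl group. The two cores differ by 4-hydroxyphenyl in place of 2-hydroxyphenyl on an aromatic carbon. The earlier change gave a 1.1-fold higher number from compound 1 to compound 2 (0.05 log units; within the scatter). For compound 4 a comparable step, a 1.1-fold higher number from compound 3 to compound 4 (0.04 log units; within the scatter), is expected because a 1.1-fold higher number from compound 1 to compound 2 (0.05 log units; within the scatter) stayed within the scatter. Compound 4 is therefore estimated at 3500 nM, between 1700 nM and 7500 nM.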

Compound 4, half-maximal inhibitory concentration: 2630 nM
The estimate for compound 4 lay 1.3-fold (0.12 log units) above the measured number; the range from low to high includes it.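

The move of the trifluoromethyl group gives a 1.2-fold lower number from compound 3 to compound 4 (0.09 log units; within the scatter), and in this assay this agrees with the same move on the other core: the same change on two cores in this assay, a 1.1-fold higher number (0.05 log units; within the scatter) from compound 1 to compound 2 and a 1.2-fold lower number (0.09 log units; within the scatter) from compound 3 to compound 4, 1.4-fold (0.13 log units) apart, within the scatter of two such steps. Among the compounds shown here, the swap of 2-hydroxyphenyl for 4-hydroxyphenyl also behaves alike on both cores, with a 2.4-fold lower number from compound 2 to compound 4 (0.38 log units; beyond the scatter) the only step here beyond the usual scatter, though it does not differ from the earlier one: the same change on two cores in this assay, a 1.8-fold lower number (0.25 log units; within the scatter) from compound 1 to compound 3 and a 2.4-fold lower number (0.38 log units; beyond the scatter) from compound 2 to compound 4, 1.4-fold (0.13 log units) apart, within the scatter of two such steps. This shows that each change carried over between these two cores, but with so few small steps it does not show that either would carry over to any other core.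

The compounds shown leave open what an amine or a carboxylic acid would do in place of the trifluoromethyl group.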